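Aryl swap at the fused bicyclic core: thiophene replacement

The source may hold more compounds than are shown below. What is called first, only, known or untested is meant among the compounds shown, and "the series" means these compounds.

Among the compounds with values here, compound 2 `C=C(Br)C(=O)Nc1cccc(-c2cn3nc(-c4ccc(OC)c(OC)c4)sc3n2)c1` gives 110 nM in a functional assay on FM3A cells (Mus musculus) for inhibition, read by cell counting, with a stated time of 2 days (a lower number here means a stronger inhibitor, a higher number a weaker inhibitor), the lowest of the two numbers so far; compound 1 `C=C(Br)C(=O)Nc1cccc(-c2cn3nc(-c4ccc(CC)cc4)sc3n2)c1` gives 3300 nM. Within the data shown here, the only measured step, a 30-fold lower number from compound 1 to compound 2 (1.48 log units; beyond the scatter), shows that the aryl group at this position moves this assay strongly. Compound 3 `C=C(Br)C(=O)Nc1cccc(-c2cn3nc(-c4cccs4)sc3n2)c1` carries thiophen-2-yl in place of 3,4-dimethoxyphenyl on an aromatic carbon. Among the measured compounds shown here, no measured step covers thiophen-2-yl, so the direction rests on the large sensitivity seen from compound 1 to compound 2; losing the 3,4-dimethoxyphenyl is expected to give a higher number. Compound 3 is expected at 1000 nM, range 200 nM to 5000 nM, a step of a 9.1-fold higher number from compound 2 to compound 3 (0.96 log units; beyond the scatter).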

Compound 3, half-maximal inhibitory concentration: 370 nM
The estimate for compound 3 lay 2.7-fold (0.43 log units) above the measured number, within the range that was stated.
By their numbers in this assay, from the lowest: compound 2; then compound 3; then compound 1.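

In this assay, the aryl position accepts a five-membered aromatic ring: a 3.4-fold higher number from compound 2 to compound 3 (0.53 log units; beyond the scatter), yet an 8.9-fold lower number from compound 1 to compound 3 (0.95 log units; beyond the scatter). Thiophen-2-yl therefore ranks between the two phenyl groups, so losing the 3,4-dimethoxyphenyl need not cost the whole gain over 4-ethylphenyl, and the order does not simply follow group size across these compounds. No supporting measurement accounts for this order. The compounds shown leave open whether a single methoxy group would match the pair, and how a furan ring, a pyridine ring or an amine on the phenyl ring would rank.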